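The compounds below may be only part of what the source reports. "The series", "measured", "known", "first", "only" and "open" are said of these compounds alone.

Measured compounds:
compound 1, `N=C(S)CCCn1nc(-c2ccccc2)ccc1=O`, 75.6%
compound 2, `CC/N=C(\S)CCn1nc(-c2ccccc2)ccc1=O`, 50.3%
compound 3, `N=C(S)CCCCCn1nc(-c2ccccc2)ccc1=O`, 91.4%

Three compounds sharing one core were tested in a functional assay on the whole organism (stomach) for inhibition, with Rattus norvegicus as the target, at a dose of 100 mg/kg by the intraduodenal route; a lower number here means less inhibition, a higher number more inhibition at the dose given (going by the name of the read-out). Compound 3 stands highest of the three: the step of a number 15.8 percentage points higher from compound 1 to compound 3 (beyond the scatter) lies beyond the scatter, and the step of a number 41.1 percentage points higher from compound 2 to compound 3 (beyond the scatter) is the largest of the set. Compound 2 is the lowest, the step of a number 25.3 percentage points lower from compound 1 to compound 2 (beyond the scatter) separating it from compound 1.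

Compound 4, `C/N=C(/S)CCCCCn1nc(-c2ccccc2)ccc1=O`, has not yet been measured. It differs from compound 3 by a group of 4 heavy atoms (2 carbon, 1 nitrogen, 1 sulfur; no ring) in place of a group of 3 heavy atoms (1 carbon, 1 nitrogen, 1 sulfur; no ring), on a saturated chain carbon, five bonds along the chain from an aromatic nitrogen. Going by the values given here, the only measured step that touches the same kind of group is a number 25.3 percentage points lower from compound 1 to compound 2 (beyond the scatter), in which a substituted version of the group replaced the unsubstituted one, though the chain changed at the same time, so it bears on compound 4 only loosely. On that basis a modest downward step is expected in this assay, a number 16.4 percentage points lower from compound 3 to compound 4 (beyond the scatter), with wide uncertainty. Compound 4 is therefore estimated at 75%, within a range from 55% to 93%.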

Compound 4, a percentage reported as inhibition, in the whole organism at one dose (the size of the read-out at that dose, not a potency): 92.3%
Compound 4: the middle estimate sits 17.3 percentage points below what was measured; low and high end bracket the measured number.
By their numbers in this assay, from the lowest: compound 2; then compound 1; then compounds 3 and 4 (each within the scatter of the next).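

In this assay, placing the group of 4 heavy atoms in place of the group of 3 heavy atoms, five bonds along the chain from an aromatic nitrogen, gives a number 0.9 percentage points higher from compound 3 to compound 4 (within the scatter), so the two compounds cannot be told apart at this position. The gaps to the other compounds remain, with a number 42 percentage points higher from compound 2 to compound 4 (beyond the scatter) and a number 16.7 percentage points higher from compound 1 to compound 4 (beyond the scatter). The substituted group therefore carries no loss on this chain, and the lower number of compound 2 cannot be assigned to substitution alone, since its chain differs as well. No available evidence accounts for this result. On these data alone, whether a longer chain would keep this level remains open, as does the effect of an amide, with oxygen in place of sulfur, at the same position.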